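The compounds below may be only part of what the source reports. "The series", "measured", "known", "first", "only" and "open" are said of these compounds alone.

The measured compounds:
Compound 1 `COc1cc(OC)c(OC)cc1/C=C/C(=O)c1ccc(OC)c2c1OC(C)(C)C=C2` gives > 10000 nM in a functional assay on HepG2 cells (Homo sapiens) for antiproliferative activity, read by MTT assay, with a stated time of 24 h (a higher number here means a weaker inhibitor, a lower number a stronger inhibitor), which is a limit of the assay and not a number.
Compound 2 `COc1ccc(C(=O)/C=C/c2ccc3ccccc3c2)c2c1C=CC(C)(C)O2` gives 210 nM.
Compound 3 `COc1ccc(C(=O)/C=C/c2ccc([N+](=O)[O-])cc2)c2c1C=CC(C)(C)O2` gives 2610 nM.

Among the numbers recorded, compound 3 stands highest, with compound 2 the nearest at a clearly lower number, while compound 1 sits at the limit (the limit of > 10000 nM in this assay, at which 1 of the 3 values shown sits). Compound 4 `COc1ccc(C(=O)/C=C/c2ccc(O)cc2)c2c1C=CC(C)(C)O2` is not yet measured. It differs from compound 3 in one place: hydroxy in place of nitro on an aromatic carbon. Within the data shown here, no single step between measured compounds is available to guide this change, so the expected step of a 1.3-fold lower number from compound 3 to compound 4 (0.12 log units; within the scatter) is estimated to stay within the scatter, in no clear direction. Compound 4 is therefore expected to give about 2000 nM, within a range from 500 nM to 8000 nM.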

Compound 4, half-maximal inhibitory concentration: > 10000 nM
Compound 4: a limit, no number (the forecaster's own chance of this, stated with the estimate: 15%); middle value at least 5.0-fold (0.69 log units) away from the limit.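

Among these compounds, this is the first step in the set between compounds that differ in one place, and it shows that the group para to a large group matters: hydroxy in place of nitro gives an at least 3.8-fold higher number from compound 3 to compound 4 (0.58 log units; beyond the scatter) in this assay. Compound 4 gives > 10000 nM, which is a limit of the assay and not a number, so the full size of this step cannot be read. Limits now make up a large share of the set: the limit of > 10000 nM in this assay, at which 2 of the 4 values shown sit.

Going by these compounds, whether an amine or a carboxylic acid at this position would give a measurable number remains open. So does whether nitro is needed at all, or whether other groups here would do as well.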